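The source may report more compounds than this note shows. Statements on the series, on what has been measured and on what is new or still open speak of the compounds shown alone.

Of the compounds shown here, two in this small set have been tested in a functional assay on the whole organism (strain NMRI) for inhibition, with Mus musculus as the target, in the formalin test, with a stated time of 30 min, at a dose of 30 umol/kg by the intraperitoneal route; a lower number here means less inhibition, a higher number more inhibition at the dose given (going by the name of the read-out). Compound 1, `S=c1[nH]nc(-c2ccccc2Sc2ccccc2Cl)o1`, carries a thione group and a chloro group; in this assay compound 1 gives 80.5%. Compound 2, `Nc1nnc(-c2ccccc2Sc2ccccc2)o1`, carries an amino group instead of the thione and has no chloro; in this assay compound 2 gives 63.7%. Of the two numbers, compound 2 stands lowest, and the nearest value, that of compound 1, lies higher by a gap beyond the usual scatter. Compound 1 and compound 2 differ in two places at once. No single step can be read between them.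

Compound 3, `Nc1nnc(-c2ccccc2Sc2ccccc2Cl)o1`, keeps the amino group of compound 2 and changes at one place: chloro in place of hydrogen on an aromatic carbon. Among the compounds with values here, no measured pair shows this change on its own. Within the data shown here, the only hint is that compound 1, which also carries the chloro, gives 80.5%, the higher of the two numbers. A modest rise in inhibition is therefore expected, though a step within the scatter would not surprise. The estimated step is a number 8.3 percentage points higher from compound 2 to compound 3 (within the scatter). Compound 3 is expected to give about 72%, within a range from 55% to 88%.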

Compound 3, a percentage reported as inhibition, in the whole organism at one dose (the size of the read-out at that dose, not a potency): 67.1%
Compound 3: the middle estimate sits 4.9 percentage points above what was measured; the range from low to high includes it.
By their numbers in this assay, from the lowest: compounds 2 and 3 (each within the scatter of the next); then compound 1.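

In this assay, chloro in place of hydrogen on an aromatic carbon, ortho to a large group, gives a number 3.4 percentage points higher from compound 2 to compound 3 (within the scatter), so with the amino group present, this change cannot be told apart from repeat-to-repeat variation. Within the data shown here, the chloro therefore cannot account for the higher number of compound 1 in this comparison, whereas keeping the chloro and exchanging the thione group for the amino group gives a number 13.4 percentage points lower from compound 1 to compound 3 (beyond the scatter), the first single-place step in this set to lie beyond the scatter. The data offer no measured explanation for either step.

From the compounds shown here alone, the effect of chloro with the thione group in place remains open, as a thione compound without chloro would be needed to test whether this step holds in that setting. Going by these compounds, it is also open whether a bromo or methoxy group at this same place, or a methylamino group or carboxylic acid in place of the amino group, would move the inhibition at this one dose by more than the scatter.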